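Compound 3: methyl in place of iodo

The source may hold more compounds than are shown below. What is called first, only, known or untested is meant among the compounds shown, and "the series" means these compounds.

Of the compounds shown here, two have measured values so far. In a functional assay on K562 cells (Homo sapiens) for cytotoxicity, read by XTT assay, with a stated time of 24 h (a lower number here means a stronger inhibitor, a higher number a weaker inhibitor), compound 1 `Cc1ccc(NC(=O)c2ccccc2OCCCCn2ccnc2)cc1Nc1nccc(-c2cccnc2)n1` gives 47500 nM and compound 2 `Cc1ccc(NC(=O)c2cc(I)ccc2OCCCCn2ccnc2)cc1Nc1nccc(-c2cccnc2)n1` gives 66500 nM with no separation beyond the scatter. Compound 3 `Cc1ccc(OCCCCn2ccnc2)c(C(=O)Nc2ccc(C)c(Nc3nccc(-c4cccnc4)n3)c2)c1` has methyl in place of iodo on an aromatic carbon, para to a 4-(1H-imidazol-1-yl)butoxy group (methyl in place of iodo on an aromatic carbon). Going by the values given here, only one measured step bears on this change: a 1.4-fold higher number from compound 1 to compound 2 (0.15 log units; within the scatter) with iodo in place of hydrogen on an aromatic carbon. Among the compounds with values here, that step stayed within the scatter, and no measured compound yet carries methyl here, so no clear shift is expected in this assay and the direction remains open. The expected size is a 1.3-fold lower number from compound 2 to compound 3 (0.12 log units; within the scatter) and so nothing beyond the scatter. For compound 3 the estimated value is 50000 nM (25000 nM to 100000 nM).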

Compound 3, half-maximal inhibitory concentration: 59500 nM
Beside the measured number, compound 3's estimate is 1.2-fold (0.08 log units) below it, within the range that was stated.
By their numbers in this assay, from the lowest: compounds 1, 3 and 2 (each within the scatter of the next).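

In this assay, the place para to a 4-(1H-imidazol-1-yl)butoxy group now has a second substituent to set against iodo, and the exchange gives a 1.1-fold lower number from compound 2 to compound 3 (0.05 log units; within the scatter). Set against hydrogen, methyl gives a 1.3-fold higher number from compound 1 to compound 3 (0.10 log units; within the scatter), so hydrogen, iodo and methyl at this place are not separated in this read-out, and the earlier single step now has two companions that also stay within the scatter. Nothing at hand explains this lack of separation.

From the compounds shown here alone, whether this place can move the number at all remains open, since all three substituents here carry no hydrogen-bond donors or acceptors and no net charge; an amine or a carboxylic acid at the same carbon would test that. Going by these compounds, whether a longer chain in place of the 4-(1H-imidazol-1-yl)butoxy group would separate from these compounds is also open.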